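Propyl in Place of Isopropyl, Tested Once More

The source may hold more compounds than are shown below. What is called first, only, known or untested is meant among the compounds shown, and "the series" means these compounds.

Compound 1 `COc1cc(N(C)CCN(C)C)c(NC(=O)/C=C\C(C)C)cc1Nc1nccc(-c2cn(C)c3ccccc23)n1` gives 4390 nM in a functional assay on HepG2 cells (Homo sapiens) for antiproliferative activity, read by MTT assay, with a stated time of 72 h; on this read-out higher numbers stand for weaker inhibition and lower numbers for stronger inhibition. Compound 2 `CCC/C=C\C(=O)Nc1cc(Nc2nccc(-c3cn(C)c4ccccc34)n2)c(OC)cc1N(C)CCN(C)C` carries the change propyl in place of isopropyl on a double-bonded chain carbon bound to a double-bonded chain carbon and gives 431 nM in this assay, so that a 10-fold lower number from compound 1 to compound 2 (1.01 log units; beyond the scatter). Compound 3 `COc1cc(N(C)CCN(C)C)c(NC(=O)/C=C\C(C)C)cc1Nc1nccc(-c2cn(C)c3ccc(F)cc23)n1` differs from compound 1 by fluoro in place of hydrogen on an aromatic carbon; in this assay compound 3 gives 3920 nM, and a 1.1-fold lower number from compound 1 to compound 3 (0.05 log units; within the scatter). Compound 4 `CCC/C=C\C(=O)Nc1cc(Nc2nccc(-c3cn(C)c4ccc(F)cc34)n2)c(OC)cc1N(C)CCN(C)C` has not been measured in this assay. It differs from compound 3 by propyl in place of isopropyl on a double-bonded chain carbon bound to a double-bonded chain carbon, the same change that separates compound 1 from compound 2, at the same place. The earlier instance of this change reads a 10-fold lower number from compound 1 to compound 2 (1.01 log units; beyond the scatter). Because the cores of compound 1 and compound 3 gave numbers separated only by a 1.1-fold lower number from compound 1 to compound 3 (0.05 log units; within the scatter), the step from compound 3 to compound 4 is expected to resemble that earlier step and is estimated as an 8.7-fold lower number from compound 3 to compound 4 (0.94 log units; beyond the scatter). This rests on a single earlier instance of the change, so the range is kept wide. Compound 4 is therefore expected to give about 450 nM in this assay, with a range from 200 nM to 1200 nM.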

Compound 4, half-maximal inhibitory concentration: 3400 nM
Estimate against measurement, compound 4: 7.6-fold (0.88 log units) below; measured number outside the range, above it.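

In this assay, propyl in place of isopropyl on a double-bonded chain carbon bound to a double-bonded chain carbon gave a much smaller result on the fluoro-bearing core, with a 1.2-fold lower number from compound 3 to compound 4 (0.06 log units; within the scatter), so the earlier step did not carry over from the core of compound 1 to the core of compound 3: the same change on two cores in this assay, a 10-fold lower number (1.01 log units; beyond the scatter) from compound 1 to compound 2 and a 1.2-fold lower number (0.06 log units; within the scatter) from compound 3 to compound 4, 8.8-fold (0.95 log units) apart, beyond the scatter of two such steps Read the other way round, fluoro in place of hydrogen on an aromatic carbon left the isopropyl pair within the scatter but not the propyl pair, with a 7.9-fold higher number from compound 2 to compound 4 (0.90 log units; beyond the scatter): the same change on two cores in this assay, a 1.1-fold lower number (0.05 log units; within the scatter) from compound 1 to compound 3 and a 7.9-fold higher number (0.90 log units; beyond the scatter) from compound 2 to compound 4, 8.8-fold (0.95 log units) apart, beyond the scatter of two such steps The two changes therefore do not add up independently in these four compounds, but this rests on one pair for each comparison and does not show why, or whether it would hold on any other core or read-out.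

As far as these compounds go, it remains open whether a longer chain such as butyl in place of propyl would show the same dependence on the fluoro group. From the compounds shown here alone, it is also open whether chloro in place of fluoro would give a number like that of compound 2 or like that of compound 4.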